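The compounds below may be only part of what the source reports. "The series", "measured", "known", "first", "only" and "open" are said of these compounds alone.

Measured compounds:
compound 1, `N/C(=N\O)c1c(Br)n(C2O[C@H](CO)[C@@H](O)[C@H]2O)c2cc(Cl)c(Cl)cc12`: 35000 nM
compound 2, `CC(=O)N/N=C/c1c(Cl)n(C2O[C@H](CO)[C@@H](O)[C@H]2O)c2cc(Cl)c(Cl)cc12`: 9000 nM

In a functional assay on KB cells (Homo sapiens) for cytotoxicity, read by spectrophotometry and crystal violet staining (a higher number here means a weaker inhibitor, a lower number a stronger inhibitor), compound 2 gives 9000 nM, the lower of the two numbers. Compound 1 gives 35000 nM in this assay, a gap beyond the scatter. Compound 3, `OC[C@H]1OC(n2c(Cl)c(/C=N/O)c3cc(Cl)c(Cl)cc32)[C@H](O)[C@@H]1O`, has not been measured. It differs from compound 2 as hydroxy in place of acetamido on a double-bonded nitrogen. Among the compounds with values here, no measured pair covers this change, so the step is uncertain. Compound 3 is expected to give 15000 nM in this assay, between 5000 nM and 50000 nM. The expected step of a 1.7-fold higher number from compound 2 to compound 3 (0.22 log units; within the scatter) is a modest loss. Compound 1 also carries hydroxy on a double-bonded nitrogen, and compound 1 gives 35000 nM.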

Compound 3, half-maximal inhibitory concentration: 25000 nM
Beside the measured number, compound 3's estimate is 1.7-fold (0.22 log units) below it, and the stated range covers the measured number.
By their numbers in this assay, from the lowest: compound 2; then compounds 3 and 1 (each within the scatter of the next).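

In this assay, within the data shown here, hydroxy in place of acetamido on a double-bonded nitrogen gives a 2.8-fold higher number from compound 2 to compound 3 (0.44 log units; beyond the scatter), the first measured step at this place, and a modest one. Acetamido and hydroxy match in hydrogen-bond donors and acceptors but differ in heavy atoms, so the result shows that this place is sensitive to the exchange even with those counts unchanged. Nothing available explains the step. From the compounds shown here alone, whether methoxy or a longer acyl chain on this nitrogen would fall closer to compound 2 or to compound 3 remains open.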